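This account rests on a few compounds, and the source may have more. Where it says the series, first, only, none or still open, it means among the compounds named here.

Working notes on the series. The compounds share one core carrying three aromatic groups. Compound 1 `Cc1ccccc1-c1cc(-c2ccc(Cl)o2)cc(-c2ccsc2)n1`, compound 2 `Clc1ccc(-c2cc(-c3ccoc3)cc(-c3ccsc3)n2)cc1` and compound 3 `Cc1ccc(-c2cc(-c3ccc(Cl)o3)cc(-c3cccs3)n2)cc1` have been measured. In a functional assay on DU-145 cells (Homo sapiens) for cytotoxicity, in the presence of a further agent that is not named here (a higher number here means a weaker inhibitor, a lower number a stronger inhibitor), compound 1 gives 24800 nM. In this assay compound 2 gives 37600 nM and compound 3 gives 19300 nM. Compound 1 stands second highest of the three numbers; its nearest neighbour is compound 3 and its furthest is compound 2, and both gaps lie within the usual scatter, so the three numbers cannot be separated.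

Compound 4 `Clc1ccc(-c2cc(-c3ccsc3)nc(-c3ccccn3)c2)o1` has not yet been measured. Relative to compound 1 it carries pyridin-2-yl in place of 2-methylphenyl on an aromatic carbon. Going by the values given here, no two measured compounds differ in this one place, so no step of this kind is known. The three measured numbers sit close together although the compounds differ in several places, which gives no ground to expect a large step here. The step from compound 1 to compound 4 is expected to be a 1.2-fold higher number from compound 1 to compound 4 (0.08 log units; within the scatter), within the scatter in either direction. For compound 4 in this assay the expected value is 30000 nM, with a range from 10000 nM to 90000 nM.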

Compound 4, half-maximal inhibitory concentration: 10900 nM
Beside the measured number, compound 4's estimate is 2.8-fold (0.44 log units) above it; low and high end bracket the measured number.
By their numbers in this assay, from the lowest: compounds 4, 3, 1 and 2 (each within the scatter of the next, the first and the last beyond it).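

In this assay, going by these compounds alone, the aromatic carbon next to the ring nitrogen responds to a change of group: pyridin-2-yl in place of 2-methylphenyl gives a 2.3-fold lower number from compound 1 to compound 4 (0.36 log units; beyond the scatter), the only step so far that isolates one place, and it lies beyond the scatter. The entering group carries a hydrogen-bond acceptor and the leaving group none, and the swap also changes the ring atoms and removes the methyl group, so this single step cannot separate these differences. Nothing at hand bears on the origin of the step.

Open, from the compounds shown here alone, is whether the step holds with other groups at the two remaining positions, as it rests on one pair. Also open, going by these compounds, is how this position would respond to a plain phenyl, a pyridin-3-yl, an amine or a carboxylic acid.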